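Shortening the chain: notes on a two-compound series

The source may report more compounds than this note shows. Statements on the series, on what has been measured and on what is new or still open speak of the compounds shown alone.

- compound 1 `CCCCCCCCCC/N=C/N1CCC(C(c2ccccc2)c2ccccc2)CC1` gives 43.1 mg/kg
- compound 2 `CCCCCCCCC/N=C/N1CCC(C(c2ccccc2)c2ccccc2)CC1` gives 40.4 mg/kg

In a functional assay on the whole organism (stomach) with Rattus norvegicus as the target (on this read-out higher numbers stand for an effect only at larger amounts of compound and lower numbers for an effect already at smaller amounts), compound 2 stands level with compound 1 within the scatter, and these two numbers are all the series offers so far. The next structure is compound 3 `CCCCCCC/N=C/N1CCC(C(c2ccccc2)c2ccccc2)CC1`, reached from compound 2 by hydrogen in place of ethyl on a saturated chain carbon, seven bonds along the chain from a double-bonded nitrogen.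

Within the data shown here, only one measured step bears on this change. It put hydrogen in place of methyl on a saturated chain carbon, nine bonds along the chain from a double-bonded nitrogen, and came to a 1.1-fold lower number from compound 1 to compound 2 (0.03 log units; within the scatter). The change now in view takes off an ethyl instead of a methyl, and a single pair shows no trend. No step beyond the scatter is therefore expected in this assay, and neither direction is favoured. The estimated step is a 1.1-fold lower number from compound 2 to compound 3 (0.03 log units; within the scatter) and remains a small one. The estimate for compound 3 is 38 mg/kg with an expected range of 20 mg/kg to 72 mg/kg at this stage of the series.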

Compound 3, dose for half-maximal effect: 33.4 mg/kg
Compound 3: middle estimate off by 1.1-fold (0.06 log units), on the high side; measured number inside the range.
By their numbers in this assay, from the lowest: compounds 3, 2 and 1 (each within the scatter of the next).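

In this assay, hydrogen in place of ethyl on a saturated chain carbon, seven bonds along the chain from a double-bonded nitrogen, gives a 1.2-fold lower number from compound 2 to compound 3 (0.08 log units; within the scatter) and thus adds a second chain change that stays within the scatter, now with a larger group leaving than the methyl of the earlier step. The wider comparison at the same place, hydrogen in place of propyl, gives a 1.3-fold lower number from compound 1 to compound 3 (0.11 log units; within the scatter) and so also stays within the scatter, which means that across these three compounds the chain can lose a propyl without a step beyond the scatter, and the three numbers cannot be separated from one another. No supporting information on hand accounts for this flat stretch of the series.

The compounds shown leave open how much further the chain can be cut before the number moves beyond the scatter. A propyl, an ethyl or a methyl are possible shorter chains. Also open, on these data alone, is what a longer chain, or a chain carrying an amine or a carboxylic acid, would do at this place.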